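Shortening the hydroxycarbamoyl chain of compound 1

A few compounds are considered here, and "the series" means these few. Any claim that something is new, unique, unknown or untested is made for them only; others in the source may bear on it.

Measured so far:
compound 1 `Nc1nc2cc(-c3nn(CCCC(=O)NO)c4ncnc(N)c34)ccc2o1`: > 50000 nM
compound 2 `Nc1ncnc2c1c(-c1cnc3[nH]ccc3c1)nn2CCCCCC(=O)NO`: 12900 nM

Both values come from a functional assay on HepG2 cells (Homo sapiens) for inhibition, read by MTT assay, with a stated time of 72 h; on this read-out higher numbers stand for weaker inhibition and lower numbers for stronger inhibition. In this assay, compound 1 gives > 50000 nM, which is a limit of the assay and not a number. Compound 1 therefore stands at the limit of > 50000 nM in this assay, at which 1 of the 2 values shown sits. Compound 2 gives a numerical value of 12900 nM.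

The next compound is compound 3 `Nc1nc2cc(-c3nn(CCC(=O)NO)c4ncnc(N)c34)ccc2o1`, which keeps the core of compound 1 and changes only the chain: hydroxycarbamoyl in place of (hydroxycarbamoyl)methyl on a saturated chain carbon, two bonds along the chain from an aromatic nitrogen. Hydroxycarbamoyl takes the place of (hydroxycarbamoyl)methyl on a saturated chain carbon, two bonds along the chain from an aromatic nitrogen, so 3-(hydroxycarbamoyl)propyl becomes 2-(hydroxycarbamoyl)ethyl. Within the data shown here, no measured pair shows the size of such a change.

The expectation rests on compound 1, with its limit of > 50000 nM. No shift beyond the scatter is expected in this assay, and a further report as a limit is likely. The expected step is a number no higher from compound 1 to compound 3 (the limit leaves the size open). For compound 3 the estimate is 50000 nM, with an expected range from 20000 nM to 120000 nM.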

Compound 3, half-maximal inhibitory concentration: > 150000 nM
Compound 3 gave a limit, no number (the forecaster's own chance of this, stated with the estimate: 65%); at least 3.0-fold (0.47 log units) between middle value and limit.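

In this assay compound 3 gives > 150000 nM, which is a limit of the assay and not a number. Compound 1 gives > 50000 nM, also a limit. No step can be read from compound 1 to compound 3: each stands only as a limit. The compounds shown leave open how far 2-(hydroxycarbamoyl)ethyl in place of 3-(hydroxycarbamoyl)propyl moves the value in this assay.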